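Series notes: cytotoxicity of two quinazoline-type amines

The source may report more compounds than this note shows. Statements on the series, on what has been measured and on what is new or still open speak of the compounds shown alone.

Measured so far:
compound 1, `CSc1nc(NCCCc2ccccc2)c2ccccc2n1` — > 100000 nM
compound 2, `[SeH]c1nc(NCc2ccccc2)c2ccccc2n1` — > 100000 nM

In an ADME assay on BEAS-2B cells (Homo sapiens) for cytotoxicity, read by MTT assay, with a stated time of 72 h (on this read-out lower numbers stand for stronger inhibition of growth and higher numbers for weaker inhibition of growth), compound 1 gives > 100000 nM, which is a limit of the assay and not a number. Compound 2 likewise gives > 100000 nM in this assay, again a limit rather than a number. Both values sit at the limit of > 100000 nM in this assay, at which 2 of the 2 values shown sit, so compound 1 cannot be placed above or below compound 2 on what is known; neither shows growth inhibition within the tested range.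

Compound 3, `CSc1nc(NCCCCCO)c2ccccc2n1`, is not yet measured. It differs from compound 1 by 2-hydroxyethyl in place of phenyl on a saturated chain carbon, three bonds along the chain from a nitrogen on an aromatic ring. Within the data shown here, with no step between measured compounds to draw on, and both known values sitting at the limit, no shift beyond the scatter is expected in this assay; the most likely outcome for compound 3 is another limit. Compound 3 is therefore expected near 150000 nM, within 50000 nM to 500000 nM, which means an expected step that the limit leaves unreadable from compound 1 to compound 3.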

Compound 3, concentration for total growth inhibition: 99400 nM
For compound 3 the middle estimate is 1.5-fold (0.18 log units) above the measured one, and the stated range covers the measured number.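

In this assay the change of 2-hydroxyethyl in place of phenyl on a saturated chain carbon, three bonds along the chain from a nitrogen on an aromatic ring, gives a number no higher from compound 1 to compound 3 (the limit leaves the size open) and so cannot be sized. Among these compounds, compound 3 gives 99400 nM as the first readable number, which shows that a change at this chain position can bring a value into the tested range. The earlier compounds shown here showed only a limit: the limit of > 100000 nM in this assay, at which 2 of the 3 values shown sit.

From the compounds shown here alone, what stays open is whether a primary amine or a carboxylic acid in place of the 2-hydroxyethyl would also give a readable number. A plain ethyl in that place would separate the loss of phenyl from the entry of the hydroxyl group.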